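This account rests on a few compounds, and the source may have more. Where it says the series, first, only, none or still open, it means among the compounds named here.

In an assay on CHO-K1 cells for displacement of a labelled ligand from melanin-concentrating hormone receptor 1 (Homo sapiens), read by scintillation proximity assay, with a stated time of 2 h (a lower number here means a stronger inhibitor, a higher number a weaker inhibitor), three compounds have been measured:

compound 1, `Cc1nc(N(C)C2CCCC2)nc2ccc(NC(=O)/C=C/c3ccc(Cl)cc3)cc12`, gives 399 nM
compound 2, `C/C(=C\C(=O)Nc1ccc2nc(N3CCC(O)(C4CC4)CC3)nc(C)c2c1)c1ccc(Cl)cc1`, gives 532 nM
compound 3, `Cc1nc(NCCNC(=O)C2CC2)nc2ccc(NC(=O)/C=C/c3ccc(OC(F)(F)F)cc3)cc12`, gives 61 nM

Compound 3 gives the lowest number of the three. The nearest to it is compound 1, and the furthest is compound 2; both gaps lie beyond the usual scatter of repeated measurements, so compound 3 stands as the strongest inhibitor among the measured compounds.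

Compound 4, `Cc1nc(NCCNS(C)(=O)=O)nc2ccc(NC(=O)/C=C/c3ccc(OC(F)(F)F)cc3)cc12`, has not yet been measured. It differs from compound 3 in a single place: methylsulfonyl in place of cyclopropylcarbonyl on an amine nitrogen. No measured pair among these three shows this particular change, so nothing here tells how large its effect will be; both groups sit on the same chain at the same amine nitrogen, and the rest of the molecule is unchanged. The expected step in this assay from compound 3 to compound 4 is a small one, either none beyond the scatter or a slight weakening, as a 1.6-fold higher number from compound 3 to compound 4 (0.21 log units; within the scatter). Compound 4 is therefore estimated at 100 nM, with a range from 35 nM to 300 nM.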

Compound 4, half-maximal inhibitory concentration: 169 nM
Compound 4: middle estimate off by 1.7-fold (0.23 log units), on the low side; the range from low to high includes it.
By their numbers in this assay, from the lowest: compound 3; then compound 4; then compounds 1 and 2 (each within the scatter of the next).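

In this assay, going by these compounds alone, this is the first single change that can be read: methylsulfonyl in place of cyclopropylcarbonyl on the amine nitrogen gives a 2.8-fold higher number from compound 3 to compound 4 (0.44 log units; beyond the scatter). The group at the end of this chain therefore affects the result, though the step is modest in size. Nothing measured here explains the step.

The swap changes two things at once, carbonyl to sulfonyl and the three-membered ring to a methyl, so the compounds shown cannot say which of them accounts for the step. An acetyl or a cyclopropylsulfonyl group on the same nitrogen would separate the two, while a free amine at the end of the chain would test whether any such group is needed there.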